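Fluorine at a second place on a sulfonamide series

The compounds below may be only part of what the source reports. "The series", "measured", "known", "first", "only" and "open" are said of these compounds alone.

Compound 1, `C[C@H](Nc1ccc(S(=O)(=O)Nc2nccs2)cc1Cl)c1ccccc1`, gives in an ADME assay on microsomes from liver (Homo sapiens) for metabolic stability, read by LC-MS, using NADPH, with a stated time of 60 min, tested at 1 uM (a higher number here means faster removal of the compound, a lower number slower removal), a value of 62 mL/min/kg. Compound 2, `C[C@H](Nc1cc(F)c(S(=O)(=O)Nc2nccs2)cc1Cl)c1ccccc1`, carries fluoro in place of hydrogen on an aromatic carbon, and in this assay compound 2 gives 108 mL/min/kg, a step of a 1.7-fold higher number from compound 1 to compound 2 (0.24 log units; within the scatter). Compound 3, `C[C@H](Nc1cc(F)c(S(=O)(=O)Nc2cscn2)cc1Cl)c1ccccc1F`, is built on a core whose difference from the core of compound 1 is not broken down here; in this assay compound 3 gives 51 mL/min/kg, a number that sits within the scatter of the value of compound 1 and beneath the value of compound 2.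

Compound 4, `C[C@H](Nc1cc(F)c(S(=O)(=O)Nc2cscn2)cc1Cl)c1cc(F)ccc1F`, has yet to be measured. It differs from compound 3 by fluoro in place of hydrogen on an aromatic carbon. For the measured compounds named here, this is the same kind of change as the one from compound 1 to compound 2, but not the same: there the new fluoro sat ortho to a group of 9 heavy atoms, meta to a group of 9 heavy atoms and para to a chloro group, whereas here it sits meta to a large group and para to a fluoro group. Resting on the measured step of a 1.7-fold higher number from compound 1 to compound 2 (0.24 log units; within the scatter), the step from compound 3 to compound 4 is expected to be a 1.2-fold higher number from compound 3 to compound 4 (0.08 log units; within the scatter). Compound 4 is therefore estimated at 62 mL/min/kg in this assay, with a likely range from 32 mL/min/kg to 120 mL/min/kg.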

Compound 4, clearance: 46 mL/min/kg
Beside the measured number, compound 4's estimate is 1.3-fold (0.13 log units) above it, within the range that was stated.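

The change from 2-fluorophenyl to 2,5-difluorophenyl gives a 1.1-fold lower number from compound 3 to compound 4 (0.04 log units; within the scatter) in this assay and so leaves the clearance of the two compounds within the scatter of each other. This does not show that the fluoro change acts alike on every core in the series: only two pairs are shown, the new fluoro stands in a different place in each, and neither step is large enough to stand clear of the scatter. What the two pairs do show is that, as far as they go, the step on one core cannot be told apart from the step on the other: the same change on two cores in this assay, a 1.7-fold higher number (0.24 log units; within the scatter) from compound 1 to compound 2 and a 1.1-fold lower number (0.04 log units; within the scatter) from compound 3 to compound 4, 1.9-fold (0.29 log units) apart, within the scatter of two such steps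

The compounds shown leave open whether a chloro, methyl or trifluoromethyl group in the place taken by the new fluoro, meta to a large group and para to a fluoro group, would give a number like that of compound 4. They also leave open how an amine or a carboxylic acid at that place would read in this assay and whether the fluoro step would hold on further cores.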